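Aryl swap on the core: expected dissociation constant of compound 4

This account rests on a few compounds, and the source may have more. Where it says the series, first, only, none or still open, it means among the compounds named here.

Compound 2 `CC(C)(C)c1ccc(-c2ccc3c(NCCCNCc4ccco4)ccnc3c2)cc1` gives 9.47 in a physicochemical assay for acid dissociation. Compound 1 `COc1cccc(CNCCCNc2ccnc3cc(-c4ccc(C(C)(C)C)cc4)ccc23)c1O` gives 9.47, and compound 3 `COc1ccc(F)cc1CNCCCNc1ccnc2cc(-c3ccc(C(C)(C)C)cc3)ccc12` gives 9.47; compound 2 stands level with both at the digits shown. The steps of no change at the digits printed from compound 1 to compound 2 (within the scatter), no change at the digits printed from compound 1 to compound 3 (within the scatter) and no change at the digits printed from compound 2 to compound 3 (within the scatter) all lie within the scatter, each changing the group on a saturated chain carbon bound to an amine nitrogen. Compound 4 `c1coc(CNCCCNc2ccnc3cc(-c4cccc5ccccc45)ccc23)c1` differs from compound 2 at an aromatic carbon: naphthalen-1-yl in place of 4-(tert-butyl)phenyl on an aromatic carbon. Within the data shown here, no measured step touches that carbon, so the three steps bear on it only as evidence that the read-out is steady across this series. The expected step of no change at the digits printed from compound 2 to compound 4 (within the scatter) is none beyond the scatter. For compound 4 the estimate is 9.47, expected between 9.1 and 9.85.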

Compound 4, acid dissociation constant: 9.47
Estimate against measurement, compound 4: no gap at the digits printed; measured number inside the range.
By their numbers in this assay, from the lowest: compounds 1, 2, 3 and 4 (each within the scatter of the next).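

Read in this assay the aromatic carbon of the shared core shows no change at the digits printed from compound 2 to compound 4 (within the scatter) and this is the first reading at that position, since the earlier steps all changed the group on the saturated chain carbon. Naphthalen-1-yl, with two six-membered aromatic rings of carbon only, therefore stands level with 4-(tert-butyl)phenyl, with one such ring and the same count of heavy atoms. No supporting measurement bears on this result.

As far as these compounds go, whether an amine or a carboxylic acid at this aromatic carbon would hold the read-out level remains open. So does the effect of a longer chain between the two amine nitrogens.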